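The source may report more compounds than this note shows. Statements on the series, on what has been measured and on what is new or still open speak of the compounds shown alone.

Series notes. In an assay on RBL-1 cells for inhibition of Polyunsaturated fatty acid 5-lipoxygenase (Rattus norvegicus) (on this read-out higher numbers stand for weaker inhibition and lower numbers for stronger inhibition), compound 1 `O=C(/C=C/c1ccc(O)c(O)c1)c1ccc(O)cc1` gives 4 nM. Compound 3 `COc1cc(C(=O)/C=C/c2ccc(O)c(O)c2)ccc1O` carries the change (methoxy in place of hydrogen on an aromatic carbon), and in this assay compound 3 gives 9 nM, so the step of a 2.3-fold higher number from compound 1 to compound 3 (0.35 log units; beyond the scatter) is modest. Compound 2 `COc1ccccc1C(=O)/C=C/c1ccc(O)c(O)c1` gives 27 nM in this assay, the highest of the three numbers; how the core of compound 2 differs from that of compound 1 is not broken down here. Compound 4 `COc1ccc(OC)c(C(=O)/C=C/c2ccc(O)c(O)c2)c1` carries the same kind of change relative to compound 2, (methoxy in place of hydrogen on an aromatic carbon), though the place is para to a methoxy group rather than ortho to a hydroxy group, so the two changes are alike in kind and not the same. Because a 2.3-fold higher number from compound 1 to compound 3 (0.35 log units; beyond the scatter) was modest, a step of a 2.0-fold higher number from compound 2 to compound 4 (0.31 log units; beyond the scatter) of similar size is expected in this assay. Compound 4 is therefore expected to give 55 nM, plausibly between 20 nM and 150 nM.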

Compound 4, half-maximal inhibitory concentration: 7.8 nM
The estimate for compound 4 lay 7.1-fold (0.85 log units) above the measured number; measured number below the stated range.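

In this assay the step of a 3.5-fold lower number from compound 2 to compound 4 (0.54 log units; beyond the scatter) runs the opposite way to the earlier step on the core of compound 1, so methoxy in place of hydrogen on an aromatic carbon does not carry a fixed shift from one core to another in this series: the same change on two cores in this assay, a 2.3-fold higher number (0.35 log units; beyond the scatter) from compound 1 to compound 3 and a 3.5-fold lower number (0.54 log units; beyond the scatter) from compound 2 to compound 4, 7.8-fold (0.89 log units) apart, beyond the scatter of two such steps.

This does not separate the effect of the core from that of the place, since in compound 4 the new methoxy is para to a methoxy group and the site differs on the other core. Two pairs also support no general rule for the series.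

Open, on these data alone, is whether methoxy at a matching place on both cores would shift the number the same way. Also open, as far as these compounds go, is whether an amine or a carboxylic acid there would follow either step.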